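The source may hold more compounds than are shown below. What is called first, only, known or untested is meant among the compounds shown, and "the series" means these compounds.

Notes on the series. Two compounds carry a number in an assay on HEK293 cells for inhibition of potassium channel subfamily T member 1 (Homo sapiens), read by thallium flux (a lower number here means a stronger inhibitor, a higher number a weaker inhibitor), so far. Compound 1 `COc1ccc(Cl)cc1NC(=O)CN1CCN(S(=O)(=O)N2CCN(S(=O)(=O)c3ccccc3)CC2)CC1` gives 1100 nM in this assay. Compound 2 `COc1ccc(F)cc1NC(=O)CN1CCN(S(=O)(=O)N2CCC(C)CC2)CC1` gives 4900 nM in this assay. Among the compounds with values here, compound 1 stands at the lower of the two numbers, and its gap to compound 2 lies beyond the usual scatter; the two structures differ in several places at once, so no single step between them is read here.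

Compound 3 `COc1ccc(Cl)cc1NC(=O)CN1CCN(S(=O)(=O)N2CCN(S(=O)(=O)c3ccc(Cl)cc3)CC2)CC1` has not yet been measured. It keeps the core of compound 1 and differs by chloro in place of hydrogen on an aromatic carbon, the change being chloro in place of hydrogen on an aromatic carbon of the outer ring of the sulfonyl group. Within the data shown here, no measured pair in this set isolates that change, so the step from compound 1 is expected to be small, in either direction, most likely within the scatter. For compound 3 the number in this assay is estimated at 900 nM, with a range from 350 nM to 2500 nM, which corresponds to an expected step of a 1.2-fold lower number from compound 1 to compound 3 (0.09 log units; within the scatter).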

Compound 3, half-maximal inhibitory concentration: 2300 nM
For compound 3 the middle estimate is 2.6-fold (0.41 log units) below the measured one; the range from low to high includes it.
By their numbers in this assay, from the lowest: compound 1; then compound 3; then compound 2.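

In this assay, chloro in place of hydrogen on an aromatic carbon of the phenylsulfonyl group, para to a large group, gives a 2.1-fold higher number from compound 1 to compound 3 (0.32 log units; beyond the scatter). Within the data shown here, this is the first single-place step, and it shows that this position is not indifferent to substitution: the change to 4-chlorophenyl is modest but moves the number the weaker way, leaving compound 1, with hydrogen there, the strongest of the three. Nothing available accounts for this step.

On these data alone, whether a nitrile, a methoxy group or an amine on the same carbon would move the number in the same direction remains open, as does the effect of chloro elsewhere on that ring. Compound 2 differs from the others in several places, so its steps cannot be read.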